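Adding a sulfur-bearing side chain to a bromo enaminone

The source may report more compounds than this note shows. Statements on the series, on what has been measured and on what is new or still open speak of the compounds shown alone.

Measured compounds:
compound 1 `CC1(C)CC(=O)C=C(Nc2ccc(Cl)cc2)C1` — 15 ug/mL
compound 2 `CC1(C)CC(=O)C=C(Nc2ccc(Br)cc2)C1` — > 50 ug/mL

Two compounds share a core and differ only in the halogen on the aromatic ring. In a functional assay on PBMC cells (Homo sapiens) for inhibition, read by thymidine incorporation, with a stated time of 72 h (on this read-out higher numbers stand for weaker inhibition and lower numbers for stronger inhibition), compound 1 gives 15 ug/mL. Compound 2 carries bromo in place of chloro, and in this assay it returns only a limit, > 50 ug/mL; this is the limit described by the limit of > 50 ug/mL in this assay, at which 1 of the 2 values shown sits, and so compound 2 stands at the weak edge of what the numbers show. Going by the values given here, the one measured step, an at least 3.3-fold higher number from compound 1 to compound 2 (0.52 log units; beyond the scatter), concerns the halogen alone.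

Compound 3 `CC1(C)CC(=O)C(C(=S)SCCO)=C(Nc2ccc(Br)cc2)C1` keeps the bromo aromatic ring of compound 2 and adds (a group of 6 heavy atoms (3 carbon, 1 oxygen, 2 sulfur; no ring) in place of a hydrogen atom, on a double-bonded ring carbon). Among the compounds with values here, no measured step touches this part of the core, so the halogen step gives no guidance on the new group; the only anchor is that compound 2 already sits at a limit. For compound 3 the account therefore expects an at least 1.2-fold lower number from compound 2 to compound 3 (0.09 log units; that floor lies within the scatter), that is, a value near the limit rather than a clear gain. The estimate for compound 3 is 40 ug/mL, with a range from 10 ug/mL to 120 ug/mL.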

Compound 3, half-maximal inhibitory concentration: 8.3 ug/mL
Compound 3: middle estimate off by 4.8-fold (0.68 log units), on the high side; the measured number lies below the stated range.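

The earlier compounds shown here varied only the halogen on the aromatic ring and said nothing about the double-bonded ring carbon of the shared core. In this assay, placing the new group of 6 heavy atoms on that carbon gives an at least 6.0-fold lower number from compound 2 to compound 3 (0.77 log units; beyond the scatter), which shows that a hydrogen atom at this position can be replaced with a clear gain in inhibition, even on the bromo aromatic ring that had given no measurable value on its own. Compound 2 is recorded only as a limit, so the step has a floor but no known full size, and how much of the gain the group brings cannot be read from these numbers: the limit of > 50 ug/mL in this assay, at which 1 of the 3 values shown sits.

The compounds shown leave open which part of the new group matters, and whether the same group would act in the same way on the chloro aromatic ring of compound 1. They also leave open how an amine, a carboxylic acid or a longer chain on this ring carbon would compare with the group in compound 3.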